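Swapping Chloro for Dimethylcarbamoyl on a Second Oxazole Core

The compounds below may be only part of what the source reports. "The series", "measured", "known", "first", "only" and "open" are said of these compounds alone.

Compound 1 `O=C(CCCCCCc1ccccc1)c1nc(Cl)co1` and compound 3 `O=C(CCCCCCc1ccccc1)c1ncc(Cl)o1` are built from the same atoms joined differently, the difference lying in the core: 5-chloro-1,3-oxazol-2-yl in place of 4-chloro-1,3-oxazol-2-yl on a carbonyl carbon. In an assay on HEK-293T cells for inhibition of diacylglycerol lipase-alpha (Homo sapiens), read by colorimetric assay (on this read-out lower numbers stand for stronger inhibition and higher numbers for weaker inhibition), compound 1 gives 2400 nM. Compound 3 reaches only a limit of this assay, > 10000 nM. The step of an at least 4.1-fold higher number from compound 1 to compound 3 (0.61 log units; beyond the scatter) is therefore known only as a bound because of the limit of > 10000 nM in this assay, at which 1 of the 3 values shown sits.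

Compound 2 `CN(C)C(=O)c1coc(C(=O)CCCCCCc2ccccc2)n1` differs from compound 1 by dimethylcarbamoyl in place of chloro on an aromatic carbon. In this assay compound 2 gives 3390 nM, so the step of a 1.4-fold higher number from compound 1 to compound 2 (0.15 log units; within the scatter) is small.

Compound 4 `CN(C)C(=O)c1cnc(C(=O)CCCCCCc2ccccc2)o1` carries the same kind of change on the core of compound 3: dimethylcarbamoyl in place of chloro on an aromatic carbon. The place differs from that in compound 2, where the group sits next to the ring nitrogen and two ring bonds from the ring oxygen, whereas here it sits next to the ring oxygen and two ring bonds from the ring nitrogen.

Resting on the step of a 1.4-fold higher number from compound 1 to compound 2 (0.15 log units; within the scatter), the step that the limit leaves unreadable from compound 3 to compound 4 is expected to be similarly small. Compound 4 is thus estimated at 15000 nM, most likely again as a limit of this assay.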

Compound 4, half-maximal inhibitory concentration: > 10000 nM
Compound 4 ended at the assay's limit; the forecaster's own chance of this, stated with the estimate: 70%; the middle value lies beyond the limit too.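

Compound 3 and compound 4 both stand at a limit of this assay, so no step between them can be read because neither value is a number: the limit of > 10000 nM in this assay, at which 2 of the 4 values shown sit.

The compounds shown leave open whether dimethylcarbamoyl in place of chloro changes the number at all on the core of compound 3, and how far either compound lies beyond the limit.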